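The compounds below may be only part of what the source reports. "The series", "measured", "known", "first", "only" and "open" are said of these compounds alone.

Measured compounds in an in vitro ADME assay on microsomes from liver (Mus musculus) for pharmacokinetics, read by LC-MS, with a stated time of 10 min, tested at 1 uM; a higher number here means faster removal of the compound, a lower number slower removal:
- compound 1 `CC(C)c1ccc(NC(=O)[C@H]2CN(C)C[C@@H]2c2ccc(/C=C/C(=O)Nc3ccccc3N)cc2)cc1`: 54 mL/min/kg
- compound 2 `CN1C[C@H](C(=O)Nc2ccc(C3CC3)cc2)[C@@H](c2ccc(/C=C/C(=O)Nc3ccccc3N)cc2)C1`: 60 mL/min/kg
- compound 3 `CN1C[C@H](C(=O)Nc2ccc(C(F)(F)F)cc2)[C@@H](c2ccc(/C=C/C(=O)Nc3ccccc3N)cc2)C1`: 23 mL/min/kg

Compound 3 has the lowest number of the three in this assay; its nearest neighbour is compound 1, and the gap between them is beyond the scatter, as is the gap to compound 2. Compound 1 and compound 2 lie within the scatter of each other, so no order is drawn between them.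

The next compound in the series is compound 4 `CN1C[C@H](C(=O)Nc2ccc(Cl)c(Cl)c2)[C@@H](c2ccc(/C=C/C(=O)Nc3ccccc3N)cc2)C1`. Relative to compound 3 the change is 3,4-dichlorophenyl in place of 4-(trifluoromethyl)phenyl on an amide-type nitrogen.

Going by the values given here, none of the measured steps touches this pair directly. The two steps that do reach compound 3, a 2.3-fold lower number from compound 1 to compound 3 (0.37 log units; beyond the scatter) and a 2.6-fold lower number from compound 2 to compound 3 (0.42 log units; beyond the scatter), both end at the trifluoromethyl group that compound 4 now loses, and both were modest. The step of a 1.1-fold higher number from compound 1 to compound 2 (0.05 log units; within the scatter) was within the scatter. Among the compounds with values here, there is no measured step from trifluoromethyl to any halogen-bearing ring, so the direction for compound 4 is open; the modest size of the two known steps into compound 3 suggests that a move away from compound 3 is more likely to be modest than large, with a higher number somewhat more plausible than a lower one.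

Compound 4 is therefore expected to show 32 mL/min/kg in this assay, within a range of 15 mL/min/kg to 65 mL/min/kg, corresponding to an estimated step of a 1.4-fold higher number from compound 3 to compound 4 (0.14 log units; within the scatter).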

Compound 4, clearance: 36 mL/min/kg
Compound 4: middle estimate off by 1.1-fold (0.05 log units), on the low side, within the range that was stated.
By their numbers in this assay, from the lowest: compounds 3, 4, 1 and 2 (each within the scatter of the next, the first and the last beyond it).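

At this position on the amide-type nitrogen, 3,4-dichlorophenyl does not separate from any of the other three rings in this assay: the steps read (a 1.6-fold higher number from compound 3 to compound 4 (0.19 log units; within the scatter)), (a 1.5-fold lower number from compound 1 to compound 4 (0.18 log units; within the scatter)) and (a 1.7-fold lower number from compound 2 to compound 4 (0.22 log units; within the scatter)). The earlier compounds shown here fell into two groups, with 4-(trifluoromethyl)phenyl set apart from 4-isopropylphenyl and 4-cyclopropylphenyl; compound 4 lies within the scatter of both groups, so the four rings now form a continuous run rather than two separate levels, even though compound 3 remains beyond the scatter of compound 1 and compound 2. No supporting measurement bears on this result, so the data give no account of the gaps seen at this position.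

The compounds shown leave open whether a ring with a single chlorine would read differently from the 3,4-dichlorophenyl ring in this assay. They also leave open whether a ring bearing a nitrile, an amine or a carboxylic acid on this amide-type nitrogen would produce a step from compound 4 that goes beyond the scatter.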